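Working notes: phenyl to 4-bromophenyl on the shared core

This account rests on a few compounds, and the source may have more. Where it says the series, first, only, none or still open, it means among the compounds named here.

Measured so far:
- compound 1 `CC1(C)[C@H]2CC[C@]1(C)N(Cc1cn(-c3ccccc3C#N)nn1)C(=O)C2`: 180 nM
- compound 2 `CC1(C)[C@H]2CC[C@]1(C)N(Cc1cn(-c3ccc(F)cc3)nn1)C(=O)C2`: 90 nM
- compound 3 `CC1(C)[C@H]2CC[C@]1(C)N(Cc1cn(-c3ccccc3)nn1)C(=O)C2`: 90 nM

All three values come from a functional assay on HepG2 cells (Homo sapiens) for inhibition, read by MTT assay, with a stated time of 24 h; on this read-out lower numbers stand for stronger inhibition and higher numbers for weaker inhibition. Compound 3 stands level with compound 2 at the digits shown, and compound 1 is its furthest neighbour, with all three numbers within the scatter of each other.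

The next compound is compound 4 `CC1(C)[C@H]2CC[C@]1(C)N(Cc1cn(-c3ccc(Br)cc3)nn1)C(=O)C2`, which carries bromo in place of hydrogen on an aromatic carbon, para to a large group (bromo in place of hydrogen on an aromatic carbon).

The nearest measured change is no change at the digits printed from compound 2 to compound 3 (within the scatter), hydrogen in place of fluoro on an aromatic carbon. Also relevant is a 2.0-fold lower number from compound 1 to compound 3 (0.30 log units; within the scatter), hydrogen in place of cyano on an aromatic carbon. A third comparison, a 2.0-fold lower number from compound 1 to compound 2 (0.30 log units; within the scatter), swaps 2-cyanophenyl for 4-fluorophenyl on an aromatic nitrogen. None of these steps goes beyond the scatter. For the measured compounds named here, no measured compound carries bromo, so the expectation rests on these small steps alone and remains uncertain.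

In this assay the expected step is a 1.1-fold higher number from compound 3 to compound 4 (0.05 log units; within the scatter), with no change expected beyond the scatter in either direction. The estimated value for compound 4 is 100 nM, with an expected range of 45 nM to 220 nM.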

Compound 4, half-maximal inhibitory concentration: 110 nM
Compound 4: the middle estimate sits 1.1-fold (0.04 log units) below what was measured; the range from low to high includes it.
By their numbers in this assay, from the lowest: compounds 2, 3, 4 and 1 (each within the scatter of the next).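

Bromo is the first group at this position larger than fluoro, and in this assay it gives a 1.2-fold higher number from compound 3 to compound 4 (0.09 log units; within the scatter), while the exchange of fluoro for bromo gives a 1.2-fold higher number from compound 2 to compound 4 (0.09 log units; within the scatter), so the read-out does not separate hydrogen, fluoro and bromo at this carbon, para to a large group. Set against the 2-cyanophenyl compound, the 4-bromophenyl group gives a 1.6-fold lower number from compound 1 to compound 4 (0.21 log units; within the scatter), so this wider exchange on the aromatic nitrogen also stays inside the scatter, and no step among the four compounds shown clears it. No independent measurement is available to explain this flat picture.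

The compounds shown leave open whether this position responds at all to a group of a different kind, such as an amine, a carboxylic acid or a longer alkyl chain in place of the halogen. They also leave open whether replacing the phenyl ring itself with a saturated ring such as cyclohexyl, with the shared core unchanged, would produce a step beyond the scatter in this assay.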